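The source may report more compounds than this note shows. Statements on the series, on what has been measured and on what is new or still open speak of the compounds shown alone.

Measured compounds:
compound 1, `COc1cc(Oc2cccc(Nc3ccccc3)c2)cc(OC)c1CNCc1ccc(C)cc1`, 3880 nM in a functional assay on HT-29 cells (Homo sapiens) for inhibition, read by MTT assay, with a stated time of 72 h; a lower number here means a stronger inhibitor, a higher number a weaker inhibitor
compound 2, `COc1cc(Oc2cccc(Nc3ccccc3)c2)cc(OC)c1CN[C@H](C)c1ccccc1`, 5120 nM in this assay

Compound 2 stands beside compound 1 within the scatter: the step of a 1.3-fold higher number from compound 1 to compound 2 (0.12 log units; within the scatter) is small. Compound 3, `COc1cc(Oc2cccc(Nc3ccccc3)c2)cc(OC)c1CNCc1ccc(Cl)cc1`, differs from compound 2 by 4-chlorobenzyl in place of 1-phenylethyl on an amine nitrogen. Among the compounds with values here, only the step of a 1.3-fold higher number from compound 1 to compound 2 (0.12 log units; within the scatter) bears on this, and it shows that exchanging one such group for another on this amine nitrogen moved the number little. No step beyond the scatter is therefore expected for a 1.3-fold lower number from compound 2 to compound 3 (0.11 log units; within the scatter). Compound 3 is estimated at 4000 nM in this assay, with a range from 1500 nM to 10000 nM.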

Compound 3, half-maximal inhibitory concentration: 3350 nM
Estimate against measurement, compound 3: 1.2-fold (0.08 log units) above; the range from low to high includes it.
By their numbers in this assay, from the lowest: compounds 3, 1 and 2 (each within the scatter of the next).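

In this assay the change to 4-chlorobenzyl on the amine nitrogen gives a 1.5-fold lower number from compound 2 to compound 3 (0.18 log units; within the scatter) and so the number stays within the scatter even though the defined stereocentre of 1-phenylethyl is gone. Chloro in place of methyl on an aromatic carbon gives a 1.2-fold lower number from compound 1 to compound 3 (0.06 log units; within the scatter) and thus shows that this smaller exchange on the benzyl ring also stays within the scatter. Nothing at hand offers a reason for these small steps.

Still open, from the compounds shown here alone, is whether an amine or a carboxylic acid on that ring, or a longer chain on the amine nitrogen, would give a step beyond the scatter. Going by these compounds, the opposite configuration of 1-phenylethyl also remains open.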